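The source may report more compounds than this note shows. Statements on the series, on what has been measured and on what is new or still open speak of the compounds shown alone.

Compound 2 `O=C(Nc1ncc(C(Oc2ccc3cc(Br)ccc3c2)c2ccc(Cl)cc2)s1)c1ccccc1` has no single number in an ADME assay on HepG2 2.2.15 cells (Homo sapiens) for cytotoxicity; on this read-out higher numbers stand for lower toxicity in this test and lower numbers for higher toxicity in this test; its result there is reported only as "not toxic" (no number reported), without a measured value. Compound 1 `CCCCCC(=O)Nc1ncc(C(Oc2ccc3cc(Br)ccc3c2)c2ccc(Cl)cc2)s1` likewise reaches only a limit in this assay, > 50000 nM, namely (the limit of > 50000 nM in this assay, at which 1 of the 2 values shown sits). Compound 3 `Cc1ccc(C(=O)Nc2ncc(C(Oc3ccc4cc(Br)ccc4c3)c3ccc(Cl)cc3)s2)cc1` differs from compound 2 by methyl in place of hydrogen on an aromatic carbon. With both measured compounds at limits, no shift beyond the usual scatter is expected in this assay from compound 2 to compound 3. Compound 3 is therefore expected to give about 60000 nM, with a plausible range from 30000 nM to 150000 nM.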

Compound 3, half-maximal cytotoxic concentration: "not toxic" (no number reported)
The entry for compound 3 holds no number; the estimate stays without a comparison.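

Compound 2 and compound 3 are both reported in this assay only as not toxic, without a number, so no step can be read between them. What the compounds shown leave open is where their actual values lie: the limit of > 50000 nM in this assay, at which 1 of the 3 values shown sits.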